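Aryl Swap on the Triazole Among Three Inactive Analogues

This account rests on a few compounds, and the source may have more. Where it says the series, first, only, none or still open, it means among the compounds named here.

Three compounds sharing one core were tested in an ADME assay on L02 cells (Homo sapiens) for antiproliferative activity, read by MTT assay, with a stated time of 48 h; on this read-out higher numbers stand for weaker inhibition and lower numbers for stronger inhibition. Compound 1 `Cc1cccc(-n2nncc2CN2C(=O)C3(C(C#N)=C(N)Oc4c3c3nc5ccccc5nc3c3ccccc43)c3ccccc32)c1` gives a value that is only a limit of the assay, > 50000 nM. Compound 2 `N#CC1=C(N)Oc2c(c3nc4ccccc4nc3c3ccccc23)C12C(=O)N(Cc1cnnn1-c1ccc(Cl)c(Cl)c1)c1ccccc12` likewise gives only a limit, > 50000 nM. Compound 3 `COc1ccccc1-n1nncc1CN1C(=O)C2(C(C#N)=C(N)Oc3c(N)cc4nc5ccccc5nc4c32)c2ccccc21` also gives only a limit, > 50000 nM. Going by the values given here, the one step between two measured compounds that differ in a single place is a step that the two limits leave unreadable from compound 1 to compound 2; its size cannot be read, since both ends are limits. Compound 3 thus stands at the limit shared by every measured compound here, (the limit of > 50000 nM in this assay, at which 3 of the 3 values shown sit), and nothing more precise about its strength is known.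

Compound 4 `Cc1ccc(Cl)cc1-n1nncc1CN1C(=O)C2(C(C#N)=C(N)Oc3c(N)cc4nc5ccccc5nc4c32)c2ccccc21` differs from compound 3 in one place: 5-chloro-2-methylphenyl in place of 2-methoxyphenyl on an aromatic nitrogen. Among the compounds with values here, the only comparable change, from compound 1 to compound 2, gives no readable size, so there is no measured guidance on how large a step to expect in this assay or in which direction. With all three measured compounds sitting at the same limit, a limit is the most probable outcome for compound 4 as well. The step from compound 3 to compound 4 is expected to be a step that the limit leaves unreadable from compound 3 to compound 4, that is, nothing that can be seen. Compound 4 is therefore estimated at 70000 nM, with a range from 25000 nM to 200000 nM, most likely reported again only as a limit.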

Compound 4, half-maximal inhibitory concentration: > 50000 nM
Compound 4: a limit, no number; the forecaster's own chance of this, stated with the estimate: 85%; the middle value lies beyond the limit too.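

In this assay compound 4 gives > 50000 nM, which is a limit and not a number. Compound 3 also sits at a limit, so the step between compound 3 and compound 4 cannot be read. The compounds shown leave open how strong each one actually is, and whether the group on the aromatic nitrogen changes that strength at all.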